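Two Compounds Level, a Third Awaiting Its Number

The compounds below may be only part of what the source reports. "The series", "measured", "known", "first", "only" and "open" are said of these compounds alone.

Values so far in a functional assay on HCT-116 cells (Homo sapiens) for inhibition, read by CCK-8 assay, with a stated time of 48 h; on this read-out higher numbers stand for weaker inhibition and lower numbers for stronger inhibition
- compound 1 `COc1ccc(CN(C(=O)CSC(=S)N2CCc3cc(OC)ccc32)c2cc(OC)c(OC)c(OC)c2)cc1` gives 9810 nM
- compound 2 `COc1cc(N(Cc2ccc(Cl)cc2)C(=O)CSC(=S)N2CCN(C(=O)OC(C)(C)C)CC2)cc(OC)c1OC` gives 8490 nM

Compound 2 at 8490 nM stands within the scatter of compound 1 at 9810 nM in this assay, so the pair cannot be ranked. Compound 3 `COc1ccc(CN(C(=O)CSC(=S)N2CCN(C(=O)OC(C)(C)C)CC2)c2cc(OC)c(OC)c(OC)c2)cc1OC` remains to be measured. It carries 3,4-dimethoxyphenyl in place of 4-chlorophenyl on a saturated chain carbon bound to an amide-type nitrogen and otherwise matches compound 2. For the measured compounds named here, no measured step shows the size of this change. The two measured compounds differ in more than one place, yet their values lie within the scatter, so no step beyond the scatter is expected. The estimated step of a 1.1-fold lower number from compound 2 to compound 3 (0.03 log units; within the scatter) is therefore expected to stay within the scatter. For compound 3 the expected value is 8000 nM, with an estimated range from 3000 nM to 20000 nM.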

Compound 3, half-maximal inhibitory concentration: > 20000 nM
Compound 3 ended at the assay's limit; the forecaster's own chance of this, stated with the estimate: 10%; middle value at least 2.5-fold (0.39 log units) away from the limit.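

In this assay, putting 3,4-dimethoxyphenyl in place of 4-chlorophenyl on a saturated chain carbon bound to an amide-type nitrogen gives an at least 2.3-fold higher number from compound 2 to compound 3 (0.37 log units; beyond the scatter) and so shows that inhibition responds to the group at this place, which the two earlier compounds, level with each other, could not show. In this assay compound 3 gives > 20000 nM as a limit of the assay and not a number. The change therefore has a known direction, towards weaker inhibition, but no full size: the limit of > 20000 nM in this assay, at which 1 of the 3 values shown sits.

For the compounds shown here, whether the weakening follows the loss of the chlorine or the arrival of the methoxy groups stays open, and the single pair cannot separate the two. A plain phenyl or a 4-fluorophenyl at this place on the core of compound 2 would bear on that question.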